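From pyridin-4-yl to propyl on the sulfur

The source may hold more compounds than are shown below. What is called first, only, known or untested is meant among the compounds shown, and "the series" means these compounds.

Values so far in a functional assay (microsomes, liver) with Rattus norvegicus as the target; on this read-out higher numbers stand for weaker inhibition and lower numbers for stronger inhibition:
compound 1 `Cc1c(C)c2c(c(C)c1N)CC(C)(CSc1ccc(F)cc1)O2` gives 220 nM
compound 2 `Cc1c(C)c2c(c(C)c1N)CC(C)(CSc1ccncc1)O2` gives 630 nM

Compound 2, at 630 nM, holds the higher of the two numbers and is the weaker inhibitor of the pair. The next compound is compound 3 `CCCSCC1(C)Cc2c(C)c(N)c(C)c(C)c2O1`, which differs from compound 2 as follows: propyl in place of pyridin-4-yl on a sulfur. In words, propyl takes the place of pyridin-4-yl on a sulfur. For the measured compounds named here, one measured step bears on this change, the modest 2.9-fold higher number from compound 1 to compound 2 (0.46 log units; beyond the scatter), which ended at the same pyridin-4-yl group. Going by the values given here, no measured compound carries a chain in that place, so the support is thin. Going by that single step, a modest move towards a lower number is expected in this assay on leaving pyridin-4-yl, with a size similar to that step. The expected move is a 2.1-fold lower number from compound 2 to compound 3 (0.32 log units; beyond the scatter). For compound 3 the estimated value is 300 nM, with an expected range of 100 nM to 900 nM.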

Compound 3, half-maximal inhibitory concentration: 280 nM
Compound 3: middle estimate off by 1.1-fold (0.03 log units), on the high side; the range from low to high includes it.
By their numbers in this assay, from the lowest: compounds 1 and 3 (each within the scatter of the next); then compound 2.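

In this assay, an aromatic ring on the sulfur is not needed to reach the lower numbers of this short series: the chain in compound 3 gives a 2.3-fold lower number from compound 2 to compound 3 (0.35 log units; beyond the scatter). Set against the 4-fluorophenyl group, propyl gives a 1.3-fold higher number from compound 1 to compound 3 (0.10 log units; within the scatter), so these two groups cannot be separated here, and pyridin-4-yl is the only one of the three that stands apart, although compound 1 also carries a six-membered aromatic ring. Nothing available gives a reason for this difference.

From the compounds shown here alone, whether the number depends on chain length remains open, as a butyl or hexyl chain on the sulfur would show. So does the effect of a terminal amine or carboxylic acid on the propyl chain, or of an oxygen in place of the sulfur.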